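Replacing 2-hydroxyphenyl with 3-hydroxyphenyl in compound 3

This account rests on a few compounds, and the source may have more. Where it says the series, first, only, none or still open, it means among the compounds named here.

Measured in a functional assay on HeLa cells (Homo sapiens) for inhibition; a higher number here means a weaker inhibitor, a lower number a stronger inhibitor:
Compound 1 `Oc1cccc(-c2cc(-c3ccccc3F)cc(-c3ccccc3O)n2)c1` gives 31100 nM
Compound 2 `Oc1ccc(-c2cc(-c3ccccc3F)cc(-c3ccccc3O)n2)cc1` gives > 50000 nM

Compound 2 gives only a limit (> 50000 nM) and not a number. Its reading is the limit of > 50000 nM in this assay, at which 1 of the 2 values shown sits, and so has no exact place on the scale.

Compound 3 `Oc1ccc(-c2cc(-c3ccccc3F)cc(-c3cccc(O)c3)n2)cc1` keeps the 4-hydroxyphenyl group of compound 2 and differs from it in one place (3-hydroxyphenyl in place of 2-hydroxyphenyl on an aromatic carbon). There, 3-hydroxyphenyl stands in place of 2-hydroxyphenyl on an aromatic carbon, next to the ring nitrogen.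

Going by the values given here, no measured step makes this exchange. The only one, an at least 1.6-fold higher number from compound 1 to compound 2 (0.20 log units; that floor lies within the scatter), concerns the other hydroxyphenyl group and leaves the 2-hydroxyphenyl group untouched. It therefore bears on the change only indirectly, and its size is known only as a floor. Compound 1, which also carries a 3-hydroxyphenyl group, gives a measurable 31100 nM in this assay, so a modest step towards a lower number is expected. Compound 3 could still end at the limit. The expected step is an at least 1.7-fold lower number from compound 2 to compound 3 (0.25 log units; that floor lies within the scatter) and remains uncertain. For compound 3 the estimate is 28000 nM, with an expected range from 9000 nM to 50000 nM in this reading.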

Compound 3, half-maximal inhibitory concentration: 14300 nM
Compound 3: middle estimate off by 2.0-fold (0.29 log units), on the high side, within the range that was stated.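

In this assay, 3-hydroxyphenyl in place of 2-hydroxyphenyl on the aromatic carbon next to the ring nitrogen brings an at least 3.4-fold lower number from compound 2 to compound 3 (0.54 log units; beyond the scatter), so this position, which the earlier step left untouched, responds to where the hydroxyl sits on its phenyl ring. That size is only a floor, as compound 2 gives a limit and not a number: the limit of > 50000 nM in this assay, at which 1 of the 3 values shown sits. The second new step has a number at both ends, a 2.2-fold lower number from compound 1 to compound 3 (0.34 log units; beyond the scatter), with 4-hydroxyphenyl in place of 2-hydroxyphenyl, and it leaves compound 3, with its 3-hydroxyphenyl and 4-hydroxyphenyl groups, as the strongest inhibitor of the three shown.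

Still open, going by these compounds, is whether the hydroxyl is needed at this position at all or whether the 2-hydroxyphenyl group is simply the poorer choice, a question that a plain phenyl, a methoxyphenyl or an aminophenyl group there could settle. Also open, on these data alone, is whether the trend holds with the 2-fluorophenyl group exchanged for another group, such as a plain phenyl or a pyridine.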